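A few compounds are considered here, and "the series" means these few. Any claim that something is new, unique, unknown or untested is made for them only; others in the source may bear on it.

Three measured compounds share one core. Compound 1 `COc1cc(N)c(Cl)cc1NC(=O)C1CCN(Cc2cccc(C)c2)CC1` gives 2.4 mg/kg in a functional assay on the whole organism for antagonist activity, with Mus musculus as the target; on this read-out higher numbers stand for an effect only at larger amounts of compound and lower numbers for an effect already at smaller amounts. Compound 2 `COc1cc(N)c(Cl)cc1NC(=O)C1CCN(Cc2ccccc2Cl)CC1` reaches only a limit of this assay, > 4 mg/kg, and this is recorded as the limit of > 4 mg/kg in this assay, at which 1 of the 3 values shown sits. Compound 3 `CCCCN1CCC(C(=O)Nc2cc(Cl)c(N)cc2OC)CC1`, the starting point of the present step, likewise gives only a limit in this assay, > 10 mg/kg, so on the numbers shown compound 3 stands at a limit rather than at a number, noted as the limit of > 10 mg/kg in this assay, at which 1 of the 3 values shown sits. Compound 4 `COc1cccc(CN2CCC(C(=O)Nc3cc(Cl)c(N)cc3OC)CC2)c1` has not been measured; it differs from compound 3 by 3-methoxyphenyl in place of propyl on a saturated chain carbon bound to an amine nitrogen in a ring. The step that bears on this change runs in the opposite direction: an at least 4.1-fold higher number from compound 1 to compound 3 (0.61 log units; beyond the scatter), a change beyond the scatter. The pair of compound 2 and compound 3 offers only two limits, a step that the two limits leave unreadable from compound 2 to compound 3, and an at least 1.6-fold higher number from compound 1 to compound 2 (0.22 log units; that floor lies within the scatter) adds little. Reversing the propyl step, compound 4 is expected to give a lower number in this assay, an at least 3.3-fold lower number from compound 3 to compound 4 (0.52 log units; beyond the scatter). The estimate for compound 4 is 3 mg/kg, expected between 1.2 mg/kg and 8 mg/kg.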

Compound 4, dose for half-maximal effect: > 4 mg/kg
Compound 4 gave a limit, no number (the forecaster's own chance of this, stated with the estimate: 25%); middle value at least 1.3-fold (0.12 log units) from the limit.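

In this assay compound 4 stands at a limit and not at a number: the limit of > 4 mg/kg in this assay, at which 2 of the 4 values shown sit. The steps that join compound 4 to compound 3 and to compound 2 cannot be read, as each joins two limits, so the exchange of propyl for 3-methoxyphenyl has no measurable size here. Among the compounds shown here, the one readable step, for methoxy in place of methyl on an aromatic carbon, is an at least 1.6-fold higher number from compound 1 to compound 4 (0.22 log units; that floor lies within the scatter), and as this floor lies within the scatter, it shows no real difference between the two groups, though it does not exclude one.

Among the compounds with an aromatic ring at this place, only compound 1 gives a number, so how far compound 4 actually lies from it stays open. Also open, as far as these compounds go, is what a hydroxyl or an amine in place of methoxy on the aromatic carbon would give.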